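Chlorophenyl to Tolyl: What the Ester Analogue May Dissolve

The source may hold more compounds than are shown below. What is called first, only, known or untested is meant among the compounds shown, and "the series" means these compounds.

Compound 1 `CCC(=O)c1cc(-c2ccc(C)cc2)n(-c2ccc(S(N)(=O)=O)cc2)c1C`: 1000 nM
Compound 2 `CCC(=O)c1cc(-c2ccccc2Cl)n(-c2ccc(S(N)(=O)=O)cc2)c1C`: 38200 nM
Compound 3 `CCOC(=O)c1cc(-c2ccccc2Cl)n(-c2ccc(S(N)(=O)=O)cc2)c1C`: 13700 nM

Of the compounds shown here, three have been measured in a physicochemical assay for solubility, read by HPLC, in phosphate buffer, measured as kinetic solubility, at pH 7.4; on this read-out lower numbers stand for lower solubility and higher numbers for higher solubility. Compound 2 stands highest, and the step of a 38-fold lower number from compound 2 to compound 1 (1.58 log units; beyond the scatter) is the largest seen here; it goes with the change (4-methylphenyl in place of 2-chlorophenyl on an aromatic carbon). The step of a 2.8-fold lower number from compound 2 to compound 3 (0.45 log units; beyond the scatter) is smaller and goes with the change (ethoxy in place of ethyl on a carbonyl carbon), which is also how the core of compound 3 differs from the core of compound 2.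

Compound 4 `CCOC(=O)c1cc(-c2ccc(C)cc2)n(-c2ccc(S(N)(=O)=O)cc2)c1C` has not yet been measured in this assay. It differs from compound 3 by 4-methylphenyl in place of 2-chlorophenyl on an aromatic carbon. Among the measured compounds shown here, this is the same kind of change as the one from compound 2 to compound 1, but the surroundings are not identical: in compound 2 the aromatic carbon sits two ring bonds from the ring atom that bears a propanoyl group (4 heavy atoms), whereas in compound 3 it sits two ring bonds from the ring atom that bears an ethoxycarbonyl group (5 heavy atoms).

Because the earlier step of a 38-fold lower number from compound 2 to compound 1 (1.58 log units; beyond the scatter) was large, a step of similar size is expected from compound 3 to compound 4, namely a 27-fold lower number from compound 3 to compound 4 (1.44 log units; beyond the scatter), starting from the number compound 3 gave, 13700 nM. For the measured compounds named here, only one prior instance of this change exists, so the expectation carries a wide range. Compound 4 is estimated to give 500 nM in this assay, with a likely span from 150 nM to 2000 nM.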

Compound 4, solubility: 1300 nM
The estimate for compound 4 lay 2.6-fold (0.41 log units) below the measured number, within the range that was stated.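

In this assay the change from 2-chlorophenyl to 4-methylphenyl carried over to the core of compound 3 with the same direction and the same large class: an 11-fold lower number from compound 3 to compound 4 (1.02 log units; beyond the scatter) stands beside a 38-fold lower number from compound 2 to compound 1 (1.58 log units; beyond the scatter) on the core of compound 2. The two cores do not stay apart once 4-methylphenyl is present, as ethoxy in place of ethyl gives a 1.3-fold higher number from compound 1 to compound 4 (0.11 log units; within the scatter) and so no difference that can be told, whereas the same change with 2-chlorophenyl present gives a 2.8-fold lower number from compound 2 to compound 3 (0.45 log units; beyond the scatter) and thus a real separation. Two pairs do not make a rule for the series, and nothing shown here explains the size of either step.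

The compounds shown leave open whether the chlorine, the methyl or the place of the substituent on the phenyl ring goes with the step, which 4-chlorophenyl and 2-methylphenyl analogues on both cores could separate. They also leave open whether the step would carry over to a core with a carboxylic acid or an amide in place of the propanoyl or ethoxycarbonyl group.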